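A few compounds are considered here, and "the series" means these few. Any claim that something is new, unique, unknown or untested is made for them only; others in the source may bear on it.

Among the compounds with values here, compound 2, with the structure `CCCCNC(=O)NCc1ccc(CCCC)n(Cc2ccc(-c3ccccc3-c3nn[nH]n3)cc2)c1=O`, stands at the lower of the two numbers so far: in a functional assay on the whole organism (artery) for inhibition, with Rattus norvegicus as the target, at a dose of 3 mg/kg by the intraduodenal route (on this read-out higher numbers stand for more inhibition at the one dose given (going by the name of the read-out) and lower numbers for less inhibition), compound 2 gives 10.3%, whereas compound 1, `CCCCc1ccc(CNC(=O)OC(C)(C)C)c(=O)n1Cc1ccc(-c2ccccc2-c2nn[nH]n2)cc1`, gives 68.9%. Within the data shown here, the one measured step, a number 58.6 percentage points lower from compound 1 to compound 2 (beyond the scatter), shows that a change in this arm of the shared core can move the read-out a great deal.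

Compound 3, `CCCCc1ccc(CN(Cc2ccccc2)C(C)=O)c(=O)n1Cc1ccc(-c2ccccc2-c2nn[nH]n2)cc1`, carries a further change in the same arm: acetyl(benzyl)amino in place of (butylcarbamoyl)amino on a saturated chain carbon bound to an aromatic carbon. Among the measured compounds shown here, no measured step covers this exact exchange, so only the step from compound 1 to compound 2 bears on it, and it was large. That step says the group on this arm matters but does not say in which direction a benzyl-bearing acetyl group without hydrogen-bond donors will move the number. A partial return toward compound 1 appears as likely as no change, so the expectation is wide.

Compound 3 is therefore expected to give about 40% in this assay, within a range from 8% to 72%, which means an expected step of a number 29.7 percentage points higher from compound 2 to compound 3 (beyond the scatter).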

Compound 3, a percentage reported as inhibition, in the whole organism at one dose (the size of the read-out at that dose, not a potency): 76.3%
Compound 3: the middle estimate sits 36.3 percentage points below what was measured; measured number outside the range, above it.
By their numbers in this assay, from the lowest: compound 2; then compounds 1 and 3 (each within the scatter of the next).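

In this assay, the low number of compound 2 turns out not to hold for every group on this arm: there is a number 66 percentage points higher from compound 2 to compound 3 (beyond the scatter) when acetyl(benzyl)amino replaces (butylcarbamoyl)amino, so this position can swing strongly in both directions. Set against the other new step, a number 7.4 percentage points higher from compound 1 to compound 3 (within the scatter), acetyl(benzyl)amino and (tert-butoxycarbonyl)amino cannot be told apart on this read-out even though they are different groups, and of the three groups shown only (butylcarbamoyl)amino stands apart from the others. Nothing among the data shown accounts for why the groups on this arm behave as they do.

From the compounds shown here alone, whether the number depends on the benzyl part or the acetyl part of the entering group remains open, as does the outcome for a plain benzylamino or acetylamino group on this saturated chain carbon. Also open, going by these compounds, is how a free amine or a carboxylic acid in this place would compare, and, as the read-out reports a single dose, how the compounds would rank in potency.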